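Methyl-to-hydrogen swap on a pyrazole urea series

The source may hold more compounds than are shown below. What is called first, only, known or untested is meant among the compounds shown, and "the series" means these compounds.

Compound 1 `COc1cc(-c2nn(-c3cccc(NC(=O)Nc4ccc(Cl)c(Cl)c4)c3)cc2-c2ccncc2)ccc1Cl` gives 1720 nM in a functional assay on SNB-19 cells (Homo sapiens) for inhibition, read by sulforhodamine B assay, with a stated time of 48 h; a higher number here means a weaker inhibitor of growth, a lower number a stronger inhibitor of growth. Compound 2 `O=C(Nc1cccc(-n2cc(-c3ccncc3)c(-c3ccc(Cl)c(O)c3)n2)c1)Nc1ccc(Cl)c(Cl)c1` differs from it by hydrogen in place of methyl on an oxygen on an aromatic ring; the measured step of a 1.2-fold lower number from compound 1 to compound 2 (0.07 log units; within the scatter) left compound 2 at 1460 nM. Compound 3 `COc1cc(-c2nn(-c3cccc(NC(=O)Nc4ccc(Cl)c(C(F)(F)F)c4)c3)cc2-c2ccncc2)ccc1Cl` carries a different change on the urea side, (trifluoromethyl in place of chloro on an aromatic carbon), and the step of a 1.4-fold lower number from compound 1 to compound 3 (0.14 log units; within the scatter) brought compound 3 to 1240 nM. Compound 4 `O=C(Nc1cccc(-n2cc(-c3ccncc3)c(-c3ccc(Cl)c(O)c3)n2)c1)Nc1ccc(Cl)c(C(F)(F)F)c1` is not yet measured; it differs from compound 3 by hydrogen in place of methyl on an oxygen on an aromatic ring. Among the measured compounds shown here, this is the same change as the one from compound 1 to compound 2: the place where it sits, on an oxygen on an aromatic ring whose other neighbours are aromatic carbon, is described in the same words for both pairs, and the two cores differ only by the change noted from compound 1 to compound 3. For the measured compounds named here, the earlier step of this change was within the scatter, so compound 4 is expected to give a similarly small step a 1.2-fold lower number from compound 3 to compound 4 (0.07 log units; within the scatter) in this assay, because the one measured instance a 1.2-fold lower number from compound 1 to compound 2 (0.07 log units; within the scatter) was small. Compound 4 is therefore estimated at 1050 nM, with a likely range from 500 nM to 2200 nM.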

Compound 4, concentration for 50% growth inhibition: 1120 nM
For compound 4 the middle estimate is 1.1-fold (0.03 log units) below the measured one, within the range that was stated.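

Methoxy to hydroxy carried from one core to the other with no visible difference, giving a 1.1-fold lower number from compound 3 to compound 4 (0.04 log units; within the scatter) in this assay: the same change on two cores in this assay, a 1.2-fold lower number (0.07 log units; within the scatter) from compound 1 to compound 2 and a 1.1-fold lower number (0.04 log units; within the scatter) from compound 3 to compound 4, 1.1-fold (0.03 log units) apart, within the scatter of two such steps. Trifluoromethyl in place of chloro carried over in the same way, giving a 1.3-fold lower number from compound 2 to compound 4 (0.12 log units; within the scatter): the same change on two cores in this assay, a 1.4-fold lower number (0.14 log units; within the scatter) from compound 1 to compound 3 and a 1.3-fold lower number (0.12 log units; within the scatter) from compound 2 to compound 4, 1.1-fold (0.03 log units) apart, within the scatter of two such steps. Among the compounds shown here, all of these steps lie within the scatter, so the agreement shows only that neither change moved the number measurably on either of these two cores; it does not show that either change has a real effect that transfers, and it does not test whether a larger step would transfer as well.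

The compounds shown leave open whether a longer chain on that oxygen, or an amine or a carboxylic acid in place of the hydroxy, would give a step beyond the scatter. They also leave open whether a nitrile in place of the trifluoromethyl would do so, and whether any such step would hold on both cores.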